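The source may report more compounds than this note shows. Statements on the series, on what has been measured and on what is new or still open speak of the compounds shown alone.

Measured so far:
compound 1, `O=c1c(C2N=C(c3ccccc3)SS2)coc2ccc(F)cc12`: 98600 nM
compound 2, `O=c1c(C2N=C(c3ccccc3)SS2)coc2cc(Cl)ccc12`: > 100000 nM

Both compounds share one core and were tested in a functional assay on HEp-2 cells (Homo sapiens) for inhibition, read by sulforhodamine B assay, with a stated time of 48 h; on this read-out lower numbers stand for stronger inhibition and higher numbers for weaker inhibition. Compound 1 gives 98600 nM. For compound 2 the assay reports only a limit, > 100000 nM, and no number. Compound 2 therefore stands at the limit of > 100000 nM in this assay, at which 1 of the 2 values shown sits, so where it sits relative to compound 1 cannot be told from these figures.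

Compound 3, `O=c1c(C2N=C(c3ccccc3)SS2)coc2cc(Cl)c(F)cc12`, has not yet been measured. It differs from compound 2 by fluoro in place of hydrogen on an aromatic carbon, a fluoro in place of hydrogen on an aromatic carbon. For the measured compounds named here, no step between two measured compounds resembles this change, so there is no measured guide to its size. The expectation is a change no larger than the usual scatter of this assay, in no clear direction. Compound 3 is therefore expected at 150000 nM, within 60000 nM to 400000 nM. The step this estimate means is a step that the limit leaves unreadable from compound 2 to compound 3, and it is expected that the assay may again report only a limit.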

Compound 3, half-maximal inhibitory concentration: 97600 nM
Estimate against measurement, compound 3: 1.5-fold (0.19 log units) above, and the stated range covers the measured number.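

For compound 2 the reading in this assay is a limit, > 100000 nM, and not a number. Fluoro in place of hydrogen on the aromatic carbon ortho to a chloro group gives an at least 1.0-fold lower number from compound 2 to compound 3 (0.01 log units; that floor lies within the scatter), which is only a floor, so the full size of this step cannot be read: the limit of > 100000 nM in this assay, at which 1 of the 3 values shown sits. Adding a chloro group gives a 1.0-fold lower number from compound 1 to compound 3 (0.00 log units; within the scatter), so with fluoro already present, the chloro group brings no difference beyond the scatter of this assay.

As far as these compounds go, whether another group on this aromatic carbon, such as an amine or a carboxylic acid, would give a number beyond the scatter remains open. From the compounds shown here alone, the true distance between compound 2 and compound 3 also stays unknown.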